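The source may report more compounds than this note shows. Statements on the series, on what has been measured and on what is new or still open speak of the compounds shown alone.

Working notes on the series. In a functional assay on A549 cells (Homo sapiens) for cytotoxicity, read by MTT assay (on this read-out lower numbers stand for stronger inhibition and higher numbers for weaker inhibition), compound 1 (`CCn1cc(C(=O)Nc2ccc(Cl)cn2)c(=O)c2cc(F)c(N3CCNC(C)C3)c(F)c21`) gives 3300 nM, compound 2 (`CCn1cc(C(=O)Nc2cc([N+](=O)[O-])ccc2F)c(=O)c2cc(F)c(N3CCNC(C)C3)c(F)c21`) gives 1700 nM and compound 3 (`CCn1cc(C(=O)Nc2ccc(C(C)=O)cc2)c(=O)c2cc(F)c(N3CCNC(C)C3)c(F)c21`) gives 4000 nM. Compound 1 stands within the scatter of both others, with a 1.9-fold lower number from compound 1 to compound 2 (0.29 log units; within the scatter) and a 1.2-fold higher number from compound 1 to compound 3 (0.08 log units; within the scatter). Only the remaining pair separates, with a 2.4-fold higher number from compound 2 to compound 3 (0.37 log units; beyond the scatter), and that step is modest.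

The next compound is compound 4 (`CCn1cc(C(=O)Nc2nccs2)c(=O)c2cc(F)c(N3CCNC(C)C3)c(F)c21`), which carries 1,3-thiazol-2-yl in place of 5-chloropyridin-2-yl on an amide-type nitrogen. Among the compounds with values here, all three measured steps are exchanges on this same amide-type nitrogen, so they are the only guide. Within the data shown here, none of the measured compounds has a five-membered aromatic ring at this place, so the new group itself is untested and the data give no direction for the change. Starting from compound 1, the two steps to compound 2 and compound 3 point in opposite directions, and both remain small in this assay. A step beyond the scatter is therefore not expected. The estimated change is a 1.1-fold lower number from compound 1 to compound 4 (0.04 log units; within the scatter). For compound 4 the expected value is 3000 nM, with an estimated range of 1300 nM to 7000 nM.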

Compound 4, half-maximal inhibitory concentration: 20200 nM
The estimate for compound 4 lay 6.7-fold (0.83 log units) below the measured number, and the stated range ends below it.
By their numbers in this assay, from the lowest: compounds 2, 1 and 3 (each within the scatter of the next, the first and the last beyond it); then compound 4.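

In this assay, this amide-type nitrogen is not indifferent to the group it carries: exchanges among 5-chloropyridin-2-yl, 2-fluoro-5-nitrophenyl and 4-acetylphenyl moved the number little, whereas 1,3-thiazol-2-yl gives a 6.1-fold higher number from compound 1 to compound 4 (0.79 log units; beyond the scatter). Within the data shown here, the weakening holds against the other two measured groups, with a 5.1-fold higher number from compound 3 to compound 4 (0.70 log units; beyond the scatter) and a 12-fold higher number from compound 2 to compound 4 (1.07 log units; beyond the scatter), the last being the largest step, so compound 4 is the weakest of the four and a five-membered aromatic ring is the first group here to separate clearly from all the others. No measurement at hand bears on the reason for this drop.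

With only one five-membered ring in the series, the compounds shown cannot say whether the higher number goes with the ring size, the ring sulfur or the loss of the chlorine. Going by these compounds, it also remains open how 1,3-oxazol-2-yl or 5-chloro-1,3-thiazol-2-yl would read on this nitrogen, and whether any five-membered aromatic ring here could return to the range of compound 1.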